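The source may hold more compounds than are shown below. What is called first, only, known or untested is meant among the compounds shown, and "the series" means these compounds.

Three analogues built on one shared core have been run through an ADME assay for permeability, using PAMPA; on this read-out higher numbers stand for higher permeability and lower numbers for lower permeability. Compound 1 `CCCC[C@H](NC(=O)[C@H](CCCCN)NC(=O)[C@H](CCCNC(=N)N)NC(=O)c1ccc(/C=C2\SC(=O)N(c3ccc(C)cc3)C2=O)cc1)C(N)=O` gives 0.66 10^-6 cm/s in this assay, and compound 2 `CCCC[C@H](NC(=O)[C@H](CCCCN)NC(=O)[C@H](CCCNC(=N)N)NC(=O)c1ccc(/C=C2\SC(=O)N(Cc3ccc(F)cc3)C2=O)cc1)C(N)=O` gives 0.43 10^-6 cm/s. Compound 3 `CCCC[C@H](NC(=O)[C@H](CCCCN)NC(=O)[C@H](CCCNC(=N)N)NC(=O)c1ccc(/C=C2\NC(=S)N(c3ccccc3)C2=O)cc1)C(N)=O` was recorded in this assay as "impermeable" (no number reported), with no number attached. Among the measured compounds shown here, of the two numbers in hand, the one for compound 2 is the lower, yet the step of a 1.5-fold lower number from compound 1 to compound 2 (0.19 log units; within the scatter) lies within the scatter, so the two compounds are not distinguished by this assay. Compound 4 `CCCC[C@H](NC(=O)[C@H](CCCCN)NC(=O)[C@H](CCCNC(=N)N)NC(=O)c1ccc(/C=C2\SC(=O)N(CCCC)C2=O)cc1)C(N)=O` differs from compound 2 in a single place: propyl in place of 4-fluorophenyl on a saturated chain carbon bound to an amide-type nitrogen in a ring Cut one bond further out, the same change reads 4-fluorobenzyl to butyl. For the measured compounds named here, the only measured step that touches the group on the amide-type nitrogen in a ring is a 1.5-fold lower number from compound 1 to compound 2 (0.19 log units; within the scatter), and it stayed within the scatter. Going by the values given here, with no step in the data pointing to a larger effect, the change expected in this assay is a 1.0-fold higher number from compound 2 to compound 4 (0.02 log units; within the scatter), nothing beyond the scatter. Compound 4 is therefore estimated at 0.45 10^-6 cm/s, with a range from 0.2 10^-6 cm/s to 1 10^-6 cm/s.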

Compound 4, apparent permeability: 1.18 10^-6 cm/s
The estimate for compound 4 lay 2.6-fold (0.42 log units) below the measured number; the whole stated range lies below it.
By their numbers in this assay, from the lowest: compounds 2, 1 and 4 (each within the scatter of the next, the first and the last beyond it).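

In this assay, among the compounds shown here, the group on the amide-type nitrogen in a ring now gives a step beyond the scatter: 4-fluorobenzyl to butyl yields a 2.7-fold higher number from compound 2 to compound 4 (0.44 log units; beyond the scatter), whereas the only earlier step at this place stayed within it. This step is modest and does not set butyl apart from every earlier group, since butyl in place of 4-methylphenyl gives a 1.8-fold higher number from compound 1 to compound 4 (0.25 log units; within the scatter), so only compound 2 and compound 4 are told apart. Nothing in hand gives a cause for the step.

Going by these compounds, what a longer chain such as hexyl, or a chain ending in an amine or a carboxylic acid, would do on this nitrogen stays open. So does whether butyl on the core of compound 3 would give a number at all in this assay.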